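Replacing 4-hydroxyphenyl with 2,4-dichlorophenyl at an assay limit

A few compounds are considered here, and "the series" means these few. Any claim that something is new, unique, unknown or untested is made for them only; others in the source may bear on it.

In a functional assay on HT-29 cells (Homo sapiens) for inhibition, read by sulforhodamine B assay, with a stated time of 48 h (on this read-out higher numbers stand for weaker inhibition of growth and lower numbers for stronger inhibition of growth), compound 1 (`O=C(Cc1csc2nc(-c3ccc(Br)cc3)cn12)N/N=C/c1ccc(O)cc1`) gives > 100000 nM as a limit, not a number. Compound 2 (`COc1cccc(OC)c1/C=N/NC(=O)Cc1csc2nc(-c3ccc(Br)cc3)cn12`) gives > 100000 nM as a limit too. Compound 3 (`O=C(Cc1csc2nc(-c3ccc(Br)cc3)cn12)N/N=C/c1ccc(Cl)cc1Cl`) differs from compound 1 by 2,4-dichlorophenyl in place of 4-hydroxyphenyl on a carbon with a double bond to nitrogen. Among the compounds with values here, the only measured change at that place is a step that the two limits leave unreadable from compound 1 to compound 2 and offers no size to carry over. With the limit of > 100000 nM in this assay, at which 2 of the 2 values shown sit, as the whole evidence, no clear shift is expected, though stronger inhibition remains possible. The expected step is an at least 1.2-fold lower number from compound 1 to compound 3 (0.09 log units; that floor lies within the scatter) and stays uncertain. For compound 3 the estimated value is 80000 nM with 20000 nM as the expected lower end and 100000 nM as the upper end.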

Compound 3, concentration for total growth inhibition: > 100000 nM
Compound 3 gave a limit, no number (the forecaster's own chance of this, stated with the estimate: 60%); middle value at least 1.2-fold (0.09 log units) from the limit.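

Within the data shown here, compound 3 also sits at a limit, so no step from compound 1 or compound 2 to compound 3 can be read: the limit of > 100000 nM in this assay, at which 3 of the 3 values shown sit. The compounds shown leave open whether 4-hydroxyphenyl, 2,6-dimethoxyphenyl and 2,4-dichlorophenyl differ at all in inhibition of growth.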